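The compounds below may be only part of what the source reports. "The series", "measured", "known", "first", "only" and "open" are said of these compounds alone.

Three linear polyamines have been tested in a functional assay on L1210 cells (Mus musculus) for inhibition, with a stated time of 96 h; a lower number here means a stronger inhibitor, a higher number a weaker inhibitor. Compound 1 `CCCNCCCNCCCN` gives 100000 nM. Compound 2 `CCCNCCCNCCCCN` differs from it by aminomethyl in place of amino on a saturated chain carbon, three bonds along the chain from an amine nitrogen, and in this assay compound 2 gives 28000 nM, the step being a 3.6-fold lower number from compound 1 to compound 2 (0.55 log units; beyond the scatter). Compound 3 `NCCCCCNCCCCN` is built from the same atoms as compound 1 joined differently; the difference between the two cores is not broken down here. In this assay compound 3 gives 180 nM, and the step from the second compound is a 160-fold lower number from compound 2 to compound 3 (2.19 log units; beyond the scatter). Compound 4 `NCCCCCNCCCCCN` has not yet been measured; it differs from compound 3 by aminomethyl in place of amino on a saturated chain carbon, four bonds along the chain from an amine nitrogen. This is the same kind of change as that separating compounds 1 and 2, though there the place was three bonds along the chain from an amine nitrogen and here four bonds. Because the earlier step was a 3.6-fold lower number from compound 1 to compound 2 (0.55 log units; beyond the scatter), a modest step is expected, a 1.8-fold lower number from compound 3 to compound 4 (0.26 log units; within the scatter). Compound 4 is accordingly estimated at 100 nM, between 30 nM and 400 nM.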

Compound 4, half-maximal inhibitory concentration: 400 nM
The estimate for compound 4 lay 4.0-fold (0.60 log units) below the measured number, within the range that was stated.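

In this assay, aminomethyl in place of amino, four bonds along the chain from an amine nitrogen, gives a 2.2-fold higher number from compound 3 to compound 4 (0.35 log units; beyond the scatter). The two pairs that carry this change differ both in the core and in the place, three bonds or four bonds along the chain from an amine nitrogen, and they do not tell which of these accounts for the result. What they do show is that the change does not carry over from one core to the other as a fixed step, or even in a fixed direction: the same change on two cores in this assay, a 3.6-fold lower number (0.55 log units; beyond the scatter) from compound 1 to compound 2 and a 2.2-fold higher number (0.35 log units; beyond the scatter) from compound 3 to compound 4, 7.9-fold (0.90 log units) apart, beyond the scatter of two such steps

The compounds shown leave open how 3-aminopropyl in the same place would read on the core of compound 3. They also leave open whether a longer chain would follow compound 4 or compound 2, and how a carboxylic acid in place of the terminal amine would fare.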